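The source may hold more compounds than are shown below. What is called first, only, known or untested is meant among the compounds shown, and "the series" means these compounds.

Measured in a functional assay on MDA-MB-231 cells (Homo sapiens) for inhibition, read by sulforhodamine B assay, with a stated time of 48 h; on this read-out lower numbers stand for stronger inhibition of growth and higher numbers for weaker inhibition of growth:
- compound 1 `NC(=O)c1cc(Br)ccc1NC(=O)/C=C/c1ccccc1` gives 2190 nM
- compound 2 `NC(=O)c1cc(I)ccc1NC(=O)/C=C/c1ccccc1` gives 596 nM

Compound 2 holds the lower of the two numbers at 596 nM. Compound 3 `NC(=O)c1cc(I)ccc1NC(=O)/C=C/c1ccccc1Cl` differs from it by one change: chloro in place of hydrogen on an aromatic carbon, phenyl to 2-chlorophenyl. Among the measured compounds shown here, the only measured step, a 3.7-fold lower number from compound 1 to compound 2 (0.57 log units; beyond the scatter), is iodo in place of bromo and leaves the phenyl untouched. It shows that a single halogen change can move this series modestly, but gives no direction for the new chloro. No clear step beyond the scatter is therefore expected in this assay. The expected step is a 1.3-fold lower number from compound 2 to compound 3 (0.12 log units; within the scatter). Compound 3 is estimated at 450 nM, with an expected range of 150 nM to 1500 nM.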

Compound 3, concentration for 50% growth inhibition: 1410 nM
Compound 3: middle estimate off by 3.1-fold (0.50 log units), on the low side; the range from low to high includes it.
By their numbers in this assay, from the lowest: compound 2; then compounds 3 and 1 (each within the scatter of the next).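

In this assay, phenyl to 2-chlorophenyl gives a 2.4-fold higher number from compound 2 to compound 3 (0.37 log units; beyond the scatter), so growth inhibition weakens. Among the compounds shown here, this is the first measured change on the phenyl, as the earlier iodo for bromo step left that group untouched. It shows that, with iodo held constant, the phenyl does not accept chloro ortho to a large group without some loss. Nothing available explains this loss. From the compounds shown here alone, it remains open whether the loss is particular to chloro or extends to other groups at this carbon, such as a methoxy or an amine.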